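This account rests on a few compounds, and the source may have more. Where it says the series, first, only, none or still open, it means among the compounds named here.

The data come from an ADME assay on HII4E cells (Mus musculus) for cytotoxicity, read by MTT assay, with a stated time of 48 h; on this read-out lower numbers stand for stronger inhibition and higher numbers for weaker inhibition. In this assay, compound 1 `CC(=O)OC[C@@H]1C=C(OC(C)=O)C(=O)[C@@H](OCC(=O)NCc2ccccc2)O1` gives 163 ug/mL, and compound 2 `CC(=O)OC[C@H]1O[C@H](OCC(=O)NCc2cn(Cc3ccccc3)nn2)[C@H](O)[C@@H](OC(C)=O)[C@H]1OC(C)=O` gives 879 ug/mL. Compound 2 therefore holds the higher of the two numbers, and its gap to compound 1 lies beyond the usual scatter of repeated measurements. Those two compounds differ in more than one place, so their gap cannot be pinned on any single group.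

Compound 3 `C=CCCCCn1cc(CNC(=O)CO[C@H]2O[C@H](COC(C)=O)[C@H](OC(C)=O)[C@H](OC(C)=O)[C@H]2O)nn1` has not been measured yet. It departs from compound 2 in a single place: pent-4-en-1-yl in place of phenyl on a saturated chain carbon bound to an aromatic nitrogen. In words, this is pent-4-en-1-yl in place of phenyl on a saturated chain carbon bound to an aromatic nitrogen. Cut one bond further out, the same change reads benzyl to hex-5-en-1-yl, so a ring gives way to an open chain with a double bond.

Going by the values given here, no measured pair shows this kind of change, which leaves only a loose guide. The step expected in this assay is a 1.3-fold lower number from compound 2 to compound 3 (0.10 log units; within the scatter), which would be no shift beyond the scatter. For compound 3 the estimated value is 700 ug/mL, with an expected range from 250 ug/mL to 1600 ug/mL.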

Compound 3, half-maximal inhibitory concentration: 63 ug/mL
For compound 3 the middle estimate is 11-fold (1.05 log units) above the measured one; measured number below the stated range.
By their numbers in this assay, from the lowest: compound 3; then compound 1; then compound 2.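

Going by these compounds alone, compound 2 and compound 3 form the first pair that differs in only one place, so this step can be pinned on a single change. In this assay, putting pent-4-en-1-yl in place of phenyl on a saturated chain carbon bound to an aromatic nitrogen gives a 14-fold lower number from compound 2 to compound 3 (1.14 log units; beyond the scatter), which shows that the read-out responds strongly to the group at this position. Within the data shown here, since a lower number stands for stronger inhibition here, the open chain with its double bond gives a clearly stronger effect on these cells than the aromatic ring does, and nothing measured so far accounts for the size of this step.

This single change removes a ring and brings in a double bond at the same time, so the compounds shown cannot say which of the two matters, or whether chain length plays a part. A saturated pentyl group would separate the ring from the double bond, while a longer chain or a terminal amine at the same place would show how far the effect extends beyond this one group.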